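A few compounds are considered here, and "the series" means these few. Any claim that something is new, unique, unknown or untested is made for them only; others in the source may bear on it.

Three compounds have been measured so far:
compound 1, `Cn1c(=O)c(S(=O)(=O)c2ccc(Cl)cc2Cl)cc2cnc(Nc3ccc4[nH]ccc4c3)nc21`, 1000 nM;
compound 2, `Cn1c(=O)c(S(=O)(=O)c2ccc(F)cc2F)cc2cnc(Nc3cccc4[nH]ccc34)nc21`, 1500 nM;
compound 3, `Cn1c(=O)c(S(=O)(=O)c2ccc(OC(=O)CCCCC3SCC4NC(=O)NC43)cc2)cc2cnc(Nc3ccc4[nH]ccc4c3)nc21`, 600 nM.

All three numbers come from a functional assay on K562 cells (Homo sapiens) for inhibition, read by trypan blue exclusion, with a stated time of 72 h; on this read-out lower numbers stand for stronger inhibition and higher numbers for weaker inhibition. On these numbers compound 1 holds the second highest place of the three. Its nearest neighbour is compound 2, whose number is higher, and the gap between them lies within the usual scatter of the measurement, so the two cannot be told apart. Its furthest neighbour is compound 3, whose number is lower, and that gap too lies within the scatter. The three compounds sit close together, and none of them can be called stronger or weaker than the others on this evidence.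

The next compound, compound 4, `Cn1c(=O)c(S(=O)(=O)c2ccc(F)cc2)cc2cnc(Nc3ccc4[nH]ccc4c3)nc21`, keeps the shared core of compound 1 and changes only the group on the sulfonyl sulfur: 4-fluorophenyl in place of 2,4-dichlorophenyl on a sulfonyl sulfur. Going by the values given here, no measured pair shows what this exact change does. The measured compounds, which differ from one another in several places, all sit within the scatter of each other; on that basis the step expected in this assay is small, probably a modest rise in the number or none beyond the scatter. Compound 4 is expected to give about 1500 nM, with a range from 500 nM to 4500 nM, which means an expected step of a 1.5-fold higher number from compound 1 to compound 4 (0.18 log units; within the scatter).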

Compound 4, half-maximal inhibitory concentration: 200 nM
For compound 4 the middle estimate is 7.5-fold (0.88 log units) above the measured one, and the stated range ends above it.
By their numbers in this assay, from the lowest: compound 4; then compounds 3, 1 and 2 (each within the scatter of the next, the first and the last beyond it).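

In this assay, going by these compounds alone, 4-fluorophenyl in place of 2,4-dichlorophenyl on a sulfonyl sulfur gives a 5.0-fold lower number from compound 1 to compound 4 (0.70 log units; beyond the scatter), the first step in this set between compounds that differ in one place, and it lies beyond the scatter. The earlier compounds shown here differ from one another in several places and all sit within the scatter of each other, so they gave no sign that the group on the sulfonyl sulfur could move the number this far. This single pair shows that the position is sensitive to the change, but no measurement shown here explains why the number falls.

The change removes the chlorines and brings in a fluorine in one move, so the pair cannot tell which of the two matters, and a plain phenyl on the sulfonyl sulfur would help to separate them. Going by these compounds, it also remains open how this position responds to groups of another kind, such as a methyl group or a ring carrying an amine or a carboxylic acid.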